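Adding a Second Bromine to a Salicylanilide

A few compounds are considered here, and "the series" means these few. Any claim that something is new, unique, unknown or untested is made for them only; others in the source may bear on it.

Compound 1, `O=C(Nc1cccc(Cl)c1)c1cc(Br)cc(Br)c1O`: 29000 nM in an assay for inhibition of HSP60/HSP10 (Homo sapiens), with a stated time of 60 min; a lower number here means a stronger inhibitor, a higher number a weaker inhibitor
Compound 2, `O=C(Nc1ccccc1)c1cc(Br)ccc1O`: limit only, see below

In this assay compound 2 gives > 100000 nM, which is a limit of the assay and not a number, as the limit of > 100000 nM in this assay, at which 1 of the 2 values shown sits, shows. Compound 3, `O=C(Nc1ccccc1)c1cc(Br)cc(Br)c1O`, has not been measured; it differs from compound 2 by bromo in place of hydrogen on an aromatic carbon. For the measured compounds named here, no measured pair isolates this change. Compound 1 also bears the entering bromo group and gives a number, so the step is expected to go toward stronger inhibition, beyond the scatter. The expected step is an at least 2.0-fold lower number from compound 2 to compound 3 (0.30 log units; that floor lies within the scatter). Compound 3 is estimated at 50000 nM, within 20000 nM to 150000 nM.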

Compound 3, half-maximal inhibitory concentration: 63000 nM
The estimate for compound 3 lay 1.3-fold (0.10 log units) below the measured number, and the stated range covers the measured number.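

Putting bromo in place of hydrogen ortho to the hydroxy group gives a compound with a real number in this assay, with an at least 1.5-fold lower number from compound 2 to compound 3 (0.20 log units; that floor lies within the scatter). Going by these compounds, compound 2 holds only a limit, so the true size of that step remains unknown: the limit of > 100000 nM in this assay, at which 1 of the 3 values shown sits. With both bromo groups present, hydrogen in place of chloro gives a 2.2-fold higher number from compound 1 to compound 3 (0.34 log units; beyond the scatter), so the chloro group also counts on this core.

On these data alone, whether a different group at the same carbon, such as an amine or a methoxy group, would serve as well as bromo remains open.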